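The compounds below may be only part of what the source reports. "The series", "measured", "known", "first", "only" and "open" are said of these compounds alone.

Series notes. Compound 1 `COc1cc(N(C)CCN(C)C)c(NC(=O)C=C(C)C)cc1Nc1nc2c(c(-c3cn(C)c4ccc(F)cc34)n1)CSCC2` and compound 2 `C/C=C\C(=O)Nc1cc(Nc2nc3c(c(-c4cn(C)c5ccc(F)cc45)n2)CSCC3)c(OC)cc1N(C)CCN(C)C` share one core; compound 3 `COc1cc(N(C)CCN(C)C)c(NC(=O)C=C(C)C)cc1Nc1nc2c(c(-c3cn(C)c4ccc(F)cc34)n1)CS(=O)(=O)CC2` and compound 4 `C/C=C\C(=O)Nc1cc(Nc2nc3c(c(-c4cn(C)c5ccc(F)cc45)n2)CS(=O)(=O)CC3)c(OC)cc1N(C)CCN(C)C` share another, and the difference between the two cores is not broken down here. In a functional assay on A549 cells (Homo sapiens) for inhibition, read by MTT assay, with a stated time of 72 h (a lower number here means a stronger inhibitor, a higher number a weaker inhibitor), compound 1 gives 902 nM, compound 2 gives 5310 nM and compound 3 gives 2140 nM. The change from compound 1 to compound 2 is prop-1-en-1-yl in place of 2-methylprop-1-en-1-yl on a carbonyl carbon, and it made a step of a 5.9-fold higher number from compound 1 to compound 2 (0.77 log units; beyond the scatter). The same kind of change, (prop-1-en-1-yl in place of 2-methylprop-1-en-1-yl on a carbonyl carbon), carries compound 3 to compound 4, on the same kind of place. If the step on the second core tracks the one on the first, compound 4 is expected to weaken by a 5.1-fold higher number from compound 3 to compound 4 (0.71 log units; beyond the scatter), because the earlier step of a 5.9-fold higher number from compound 1 to compound 2 (0.77 log units; beyond the scatter) is the only guide. The estimate for compound 4 in this assay is 11000 nM, with a range of 5000 nM to 28000 nM.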

Compound 4, half-maximal inhibitory concentration: 3990 nM
The estimate for compound 4 lay 2.8-fold (0.44 log units) above the measured number; the whole stated range lies above it.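

In this assay, prop-1-en-1-yl in place of 2-methylprop-1-en-1-yl on the carbonyl carbon gives a 1.9-fold higher number from compound 3 to compound 4 (0.27 log units; within the scatter), so on this core the change does not separate the two compounds. The step seen on the core of compound 1 does not carry over at the same size to the core of compound 3: the same change on two cores in this assay, a 5.9-fold higher number (0.77 log units; beyond the scatter) from compound 1 to compound 2 and a 1.9-fold higher number (0.27 log units; within the scatter) from compound 3 to compound 4, 3.2-fold (0.50 log units) apart, beyond the scatter of two such steps. Going by these compounds alone, with only two pairs, this shows that the step size differs between these two cores, but it does not show which feature of the cores accounts for the gap or how the change would behave on any further core.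

Still open, on these data alone, is whether a longer chain or an amine-bearing chain on the carbonyl carbon would also give steps that differ between the two cores.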